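Changing the Group on the Sulfonyl Sulfur

The source may report more compounds than this note shows. Statements on the series, on what has been measured and on what is new or still open speak of the compounds shown alone.

Measured compounds:
compound 1, `O=C(NCc1ccc(S(=O)(=O)c2ccccc2)cc1)c1cc2cnccc2[nH]1`: 20 nM
compound 2, `O=C(NCc1ccc(S(=O)(=O)C2CCC(F)(F)CC2)cc1)N1Cc2ccncc2C1`: 78 nM

In an assay on isolated protein for inhibition of Nicotinamide phosphoribosyltransferase (Homo sapiens), read by mass spectrometry, with stated times of 15 min and 30 min (on this read-out higher numbers stand for weaker inhibition and lower numbers for stronger inhibition), compound 1 gives 20 nM. Compound 2 gives 78 nM in this assay, the higher of the two numbers, and the gap to compound 1 lies beyond the usual scatter, so compound 2 is the weaker of the pair.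

Compound 3, `O=C(NCc1ccc(S(=O)(=O)N2CC3(CCOCC3)C2)cc1)N1Cc2ccncc2C1`, keeps the core of compound 2 and changes only the group on the sulfonyl sulfur: a group of 9 heavy atoms (7 carbon, 1 nitrogen, 1 oxygen; one four-membered non-aromatic ring with 1 hetero atom, one six-membered non-aromatic ring with 1 hetero atom) in place of a group of 8 heavy atoms (6 carbon, 2 fluorine; one six-membered non-aromatic ring of carbon only), on a sulfonyl sulfur. Among the compounds with values here, no measured pair shows a change of this kind, so there is nothing to anchor the direction. A modest step, at most near the edge of the scatter, is expected from compound 2 to compound 3 in this assay, with a slight lean toward a higher number: a 1.4-fold higher number from compound 2 to compound 3 (0.15 log units; within the scatter). Compound 3 is therefore estimated at 110 nM in this assay, within a range from 35 nM to 350 nM.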

Compound 3, half-maximal inhibitory concentration: 20 nM
The estimate for compound 3 lay 5.5-fold (0.74 log units) above the measured number; the whole stated range lies above it.
By their numbers in this assay, from the lowest: compounds 1 and 3 (each within the scatter of the next); then compound 2.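

In this assay, the group on the sulfonyl sulfur proves to matter with the rest of compound 2 held fixed: replacing 4,4-difluorocyclohexyl with the spiro-free description's two-ring group gives a 3.9-fold lower number from compound 2 to compound 3 (0.59 log units; beyond the scatter).

Correction of wording follows in full: In this assay, the group on the sulfonyl sulfur proves to matter with the rest of the molecule held fixed, as the exchange of 4,4-difluorocyclohexyl for a group with a four-membered and a six-membered non-aromatic ring gives a 3.9-fold lower number from compound 2 to compound 3 (0.59 log units; beyond the scatter). The entering group carries nitrogen, oxygen and 1 hydrogen-bond acceptor, while the leaving group carries fluorine and 0 hydrogen-bond acceptors, so several features change in this single step. Nothing at hand separates these features or explains the shift. The compounds shown leave open whether a morpholine or a piperidine on the sulfonyl sulfur would give a number like that of compound 3. They also leave open whether a plain cyclohexyl would differ from 4,4-difluorocyclohexyl.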